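Swapping a nitrile for a tetrazole on the shared core

This account rests on a few compounds, and the source may have more. Where it says the series, first, only, none or still open, it means among the compounds named here.

Compound 1, `O=c1[nH]cc(-c2ccc(F)cc2)cc1O`: in an ADME assay on HEK293 cells (Homo sapiens) for cytotoxicity, read by MTT assay, with a stated time of 4 days (a lower number here means a stronger inhibitor, a higher number a weaker inhibitor), compound 1 reaches only a limit, > 100000 nM.
Compound 2, `N#Cc1ccc(-c2c[nH]c(=O)c(O)c2)cc1`: in this assay compound 2 also reaches only a limit, > 100000 nM.

Compound 2 therefore stands at the edge of what this assay can report, not at a number; this is the point described by the limit of > 100000 nM in this assay, at which 2 of the 2 values shown sit. Among the compounds with values here, the only measured step, a step that the two limits leave unreadable from compound 1 to compound 2, cannot be sized for the same reason. Compound 3, `O=c1[nH]cc(-c2ccc(-c3nnn[nH]3)cc2)cc1O`, changes one feature of compound 2: 1H-tetrazol-5-yl in place of cyano on an aromatic carbon. Within the data shown here, no measured step involves a tetrazole, so there is no guide to a direction, and the one step that exists is unreadable. The expectation for this assay is therefore no step beyond the scatter, with compound 3 most likely returning another limit. Compound 3 is expected at roughly 150000 nM, within 50000 nM to 500000 nM. The expected step is then a step that the limit leaves unreadable from compound 2 to compound 3.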

Compound 3, half-maximal inhibitory concentration: 80000 nM
Compound 3: the middle estimate sits 1.9-fold (0.27 log units) above what was measured, and the stated range covers the measured number.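

In this assay, within the data shown here, compound 3 is the only one of the three compounds with a measured number rather than a limit, so a change at this aromatic carbon can bring the reading inside the range the assay reports. The result reads as an at least 1.2-fold lower number from compound 2 to compound 3 (0.09 log units; that floor lies within the scatter), and as an at least 1.2-fold lower number from compound 1 to compound 3 (0.09 log units; that floor lies within the scatter). Each step is known only as a floor, because its other end is a limit: the limit of > 100000 nM in this assay, at which 2 of the 3 values shown sit.

The compounds shown leave open how large either step really is, and so whether 1H-tetrazol-5-yl truly differs from cyano or fluoro here. A carboxylic acid or an amine on the same aromatic carbon would help show whether a measurable number is particular to the tetrazole or also appears with other groups at this place.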